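Nitro to Amino Exchange on Two Cores

A few compounds are considered here, and "the series" means these few. Any claim that something is new, unique, unknown or untested is made for them only; others in the source may bear on it.

Compound 1 `COC(=O)c1c(-c2ccc([N+](=O)[O-])cc2)oc2ccccc2c1=O` and compound 2 `COC(=O)c1c(-c2ccc(N)cc2)oc2ccccc2c1=O` share one core, while compound 3 `O=c1cc(-c2ccc([N+](=O)[O-])cc2)oc2cc(O)ccc12` and the unmeasured compound 4 `Nc1ccc(-c2cc(=O)c3ccc(O)cc3o2)cc1` share another. How the core of compound 3 differs from the core of compound 1 is not broken down here; the two differ in more than one place.

In a functional assay on A549 cells (Homo sapiens) for cytotoxicity, read by MTT assay, with a stated time of 6 days (a higher number here means that more compound is needed for the effect, a lower number that less compound is needed), compound 1 gives > 25 ug/mL, which is a limit of the assay and not a number. In this assay compound 2 gives > 25 ug/mL, again a limit. Compound 3 is the only one of the three with a number, giving 21.8 ug/mL in this assay.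

The change amino in place of nitro on an aromatic carbon led to a step that the two limits leave unreadable from compound 1 to compound 2; the step cannot be read because the limit of > 25 ug/mL in this assay, at which 2 of the 3 values shown sit, holds both of its end points. The change amino in place of nitro on an aromatic carbon is the same change, with the place described in the same words, now made on the core of compound 3.

Among the measured compounds shown here, from compound 3 to compound 4 the step of a 1.1-fold higher number from compound 3 to compound 4 (0.06 log units; within the scatter) is expected, resting on compound 3 at 21.8 ug/mL as the only number available and on a step that the two limits leave unreadable from compound 1 to compound 2 giving no readable direction for the same exchange. For compound 4 in this assay the estimate is 25 ug/mL, expected to fall between 12 ug/mL and 50 ug/mL, with a fair chance that only a limit is reported.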

Compound 4, concentration for half-maximal effect: 8.87 ug/mL
The estimate for compound 4 lay 2.8-fold (0.45 log units) above the measured number, and the stated range ends above it.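

On the core of compound 3, amino in place of nitro on an aromatic carbon gives a 2.5-fold lower number from compound 3 to compound 4 (0.39 log units; beyond the scatter) in this assay, so less compound is needed for the effect once the amino group is present, and the step is modest but beyond the scatter. The same exchange on the core of compound 1 cannot be read, because neither end of that step carries a number: the limit of > 25 ug/mL in this assay, at which 2 of the 4 values shown sit. This pair therefore neither supports nor contradicts the step seen on the core of compound 3, so the series gives a readable size and direction for this change on one core only and does not show that either carries from one core to another.

The compounds shown leave open whether the step belongs to the amino group itself or would also appear with another group at that aromatic carbon, such as an acetamide, a dimethylamino group or a carboxylic acid. They also leave open whether the exchange would give a readable step on any core other than that of compound 3, since a single pair with numbers at both ends cannot establish a trend across the series.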